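Propoxy in Place of Acetamido: Expecting No Change

This account rests on a few compounds, and the source may have more. Where it says the series, first, only, none or still open, it means among the compounds named here.

Compound 1 `CC(=O)Nc1ccc(/C=N/Nc2nc(N)c3ncn([C@@H]4O[C@H](CO)[C@@H](O)[C@H]4O)c3n2)cc1` was tested in an assay on CHO-K1 cells for displacement of a labelled ligand from adenosine receptor A1 (Homo sapiens), read by scintillation counting, with a stated time of 60 min, tested at 1 uM (a higher number here means more inhibition at the concentration tested (going by the name of the read-out), a lower number less inhibition), and gave 0%. In this assay compound 2 `Nc1nc(N/N=C/c2ccc(OCc3ccccc3)c(OCc3ccccc3)c2)nc2c1ncn2[C@@H]1O[C@H](CO)[C@@H](O)[C@H]1O` gave 0%, and compound 3 `Nc1nc(N/N=C/c2ccc(C(F)(F)F)cc2C(F)(F)F)nc2c1ncn2[C@@H]1O[C@H](CO)[C@@H](O)[C@H]1O` gave 0%. On these numbers compound 1 stands level with compound 2 and compound 3 at the digits shown; none of the three produces a measurable displacement at the concentration tested.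

Compound 4 `CCCOc1ccc(/C=N/Nc2nc(N)c3ncn([C@@H]4O[C@H](CO)[C@@H](O)[C@H]4O)c3n2)cc1` has not yet been measured. It differs from compound 1 in one place: propoxy in place of acetamido on an aromatic carbon. Cut one bond further out, the same difference reads 4-acetamidophenyl to 4-propoxyphenyl, on an aromatic carbon of a six-membered aromatic ring of carbon only, para to a large group.

Among the measured compounds shown here, no step between measured compounds is available, so nothing shows directly how such a swap moves the read-out. Three differently substituted compounds all sit at the same floor, which gives no sign that this position is sensitive. The step from compound 1 to compound 4 is therefore expected to be no change at the digits printed from compound 1 to compound 4 (within the scatter), nothing beyond the scatter. Compound 4 is expected to give 0%, estimated between -5% and 12%.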

Compound 4, a percentage reported as inhibition, at one concentration (the size of the read-out at that concentration, not a potency): 7%
The estimate for compound 4 lay 7 percentage points below the measured number; the range from low to high includes it.
By their numbers in this assay, from the lowest: compounds 1, 2, 3 and 4 (each within the scatter of the next).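

Putting propoxy in place of acetamido on this aromatic carbon gives a number 7 percentage points higher from compound 1 to compound 4 (within the scatter) in this assay and so provides the one direct, single-place comparison in this set. In this pair, replacing a group that has a hydrogen-bond donor with one that has none does not move the read-out beyond the scatter, so the position shows no sensitivity to this particular change. No measured property is available to explain the result.

From the compounds shown here alone, whether an amine, a carboxylic acid or a longer alkoxy chain such as hexyloxy in the same place would lift the read-out clear of the scatter remains open. A reading at a single concentration also leaves open how these compounds would compare at higher concentrations.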